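The compounds below may be only part of what the source reports. "The series", "measured", "known", "first", "only" and "open" are said of these compounds alone.

In a functional assay on MKN-28 cells (Homo sapiens) for inhibition, read by colorimetric assay and sulforhodamine B assay, with a stated time of 48 h (a lower number here means a stronger inhibitor of growth, a higher number a weaker inhibitor of growth), three compounds sharing one core have been measured: compound 1 (`CCCCCCCCCCCC[C@@H](O)[C@H]1CC[C@H]([C@H](O)CCCCCCCCCCNC(=O)c2cccs2)O1`) gives 363 nM, compound 2 (`CCCCCCCCCCCC[C@@H](O)[C@H]1CC[C@H]([C@H](O)CCCCCCCCCCNC(=O)c2ccoc2)O1`) gives 550 nM and compound 3 (`CCCCCCCCCCCC[C@@H](O)[C@H]1CC[C@H]([C@H](O)CCCCCCCCCCNC(=O)c2ccsc2)O1`) gives 575 nM. Compound 3 thus stands level with the other two, with every gap inside the scatter. Compound 4 (`CCCCCCCCCCCC[C@@H](O)[C@H]1CC[C@H]([C@H](O)CCCCCCCCCCNC(=O)c2ccnn2C)O1`) alters one place only: 1-methyl-1H-pyrazol-5-yl in place of thiophen-3-yl on a carbonyl carbon. The closest evidence comes from other swaps on that same carbonyl carbon: a 1.5-fold higher number from compound 1 to compound 2 (0.18 log units; within the scatter), a 1.6-fold higher number from compound 1 to compound 3 (0.20 log units; within the scatter) and a 1.0-fold higher number from compound 2 to compound 3 (0.02 log units; within the scatter). None of these involves 1-methyl-1H-pyrazol-5-yl, so the evidence is indirect, and no step beyond the scatter is expected in either direction. The expected change is a 1.0-fold higher number from compound 3 to compound 4 (0.02 log units; within the scatter). Compound 4 is estimated at 600 nM, with an expected range of 250 nM to 1500 nM.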

Compound 4, concentration for 50% growth inhibition: 10 nM
Compound 4: middle estimate off by 60-fold (1.78 log units), on the high side, and the stated range ends above it.
By their numbers in this assay, from the lowest: compound 4; then compounds 1, 2 and 3 (each within the scatter of the next).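

In this assay the three earlier rings on this carbonyl carbon sat within the scatter of one another, so the position looked insensitive to the choice of ring. 1-methyl-1H-pyrazol-5-yl overturns that view, with large steps against all three (a 58-fold lower number from compound 3 to compound 4 (1.76 log units; beyond the scatter)) (a 55-fold lower number from compound 2 to compound 4 (1.74 log units; beyond the scatter)) (a 36-fold lower number from compound 1 to compound 4 (1.56 log units; beyond the scatter)). The group on this carbonyl carbon can therefore strongly change growth inhibition, though nothing here explains why. From the compounds shown here alone, it remains open whether the gain needs the methyl or the second ring nitrogen. A 1H-pyrazol-5-yl without the methyl, or a pyridinyl group, would help separate these.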